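Swapping a Methoxy for a Tetrazole: Solubility Outlook

The compounds below may be only part of what the source reports. "The series", "measured", "known", "first", "only" and "open" are said of these compounds alone.

Compound 1 `COc1ccnc(Nc2cc3[nH]c(-c4cccc(C(F)(F)F)c4)nc3cn2)c1` was tested in a physicochemical assay for solubility, using the shake flask method, in phosphate buffer, measured as kinetic solubility, with a stated time of 20 h, at pH 6.5; on this read-out lower numbers stand for lower solubility and higher numbers for higher solubility. In this assay compound 1 gives only a limit, < 5000 nM. Compound 2 `N#Cc1ccc(Nc2cc3[nH]c(-c4cccc(C(F)(F)F)c4)nc3cn2)nc1` likewise gives only a limit, < 5000 nM. Within the data shown here, the single measured step, a step that the two limits leave unreadable from compound 1 to compound 2, is therefore unreadable, since (the limit of < 5000 nM in this assay, at which 2 of the 2 values shown sit). Compound 3 `FC(F)(F)c1cccc(-c2nc3cnc(Nc4cc(-c5nnn[nH]5)ccn4)cc3[nH]2)c1` differs from compound 1 by 1H-tetrazol-5-yl in place of methoxy on an aromatic carbon. Among the measured compounds shown here, no measured step covers this change, so its size and direction in this assay remain open. Compound 3 is expected to give 8000 nM, between 2000 nM and 40000 nM, which means an expected step of an at least 1.6-fold higher number from compound 1 to compound 3 (0.20 log units; that floor lies within the scatter).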

Compound 3, solubility: < 5000 nM
Compound 3: a limit, no number; the forecaster's own chance of this, stated with the estimate: 50%; middle value at least 1.6-fold (0.20 log units) from the limit.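

In this assay compound 3 gives only a limit, < 5000 nM. The step from compound 1 to compound 3 therefore cannot be read: the limit of < 5000 nM in this assay, at which 3 of the 3 values shown sit. From the compounds shown here alone, whether 1H-tetrazol-5-yl in place of methoxy changes the read-out at all, and in which direction, stays open.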